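Swapping the thiophene amide for a bromomethylphenyl amide

A few compounds are considered here, and "the series" means these few. Any claim that something is new, unique, unknown or untested is made for them only; others in the source may bear on it.

Three amides built on one shared core have been tested in an ADME assay on MT4 cells (Homo sapiens) for cytotoxicity, read by MTT assay, with a stated time of 5 days; a higher number here means that more compound is tolerated, a lower number that less compound is tolerated. Compound 1 `O=C(CSc1snnc1-c1ccc(Br)cc1Br)Nc1ccccc1` gives 24800 nM. Compound 2 `Cc1cccc(NC(=O)CSc2snnc2-c2ccc(Br)cc2Br)c1C` gives 241000 nM. Compound 3 `COC(=O)c1ccsc1NC(=O)CSc1snnc1-c1ccc(Br)cc1Br` reaches only a limit of the assay at > 227000 nM, so its true value is not known; this is recorded as the limit of > 227000 nM in this assay, at which 1 of the 3 values shown sits. On the numbers shown, compound 3 therefore stands at or beyond the high end, alongside compound 2, while compound 1 sits lowest.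

The step now followed leads to compound 4 `Cc1ccc(NC(=O)CSc2snnc2-c2ccc(Br)cc2Br)c(Br)c1`, in which (2-bromo-4-methylphenyl in place of 3-(methoxycarbonyl)thiophen-2-yl on an amide-type nitrogen). The measured steps that bear on it are a 9.7-fold higher number from compound 1 to compound 2 (0.99 log units; beyond the scatter) and an at least 9.1-fold higher number from compound 1 to compound 3 (0.96 log units; beyond the scatter): both replacements of a plain phenyl on the amide nitrogen raised the tolerated amount by about the same modest amount. The change a step that the limit leaves unreadable from compound 2 to compound 3 cannot be sized.

Compound 4 carries a substituted phenyl on the amide nitrogen, as compound 2 does, so its tolerated amount is expected to lie close to that of compound 2 and below the limit of compound 3, with an at least 1.5-fold lower number from compound 3 to compound 4 (0.17 log units; that floor lies within the scatter) as the expected step, downward but possibly within the scatter. Compound 4 is thus estimated at 150000 nM, between 40000 nM and 300000 nM.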

Compound 4, half-maximal cytotoxic concentration: > 216000 nM
Compound 4 ended at the assay's limit (the forecaster's own chance of this, stated with the estimate: 25%); middle value at least 1.4-fold (0.15 log units) from the limit.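

In this assay compound 4 reaches only a limit of the assay, not a number: the limit of > 216000 nM in this assay, at which 1 of the 4 values shown sits. Against the plain phenyl amide there is an at least 8.7-fold higher number from compound 1 to compound 4 (0.94 log units; beyond the scatter), so among the four compounds all three replacements of phenyl on an amide-type nitrogen raise the number, none goes against this, and the 2-bromo-4-methylphenyl group, a six-membered aromatic ring of carbon only with no hydrogen-bond acceptors, does so as well as the 3-(methoxycarbonyl)thiophen-2-yl group with its ester. The steps to compound 4 from compound 2 and from compound 3 cannot be read, so no order can be given among these three compounds.

Going by these compounds, how far compound 3 and compound 4 lie past their limits stays unknown, and so does whether the bromine or the methyl on the ring of compound 4 accounts for its step from compound 1. Also open, on these data alone, is what a phenyl ring carrying a carboxylic acid or an amine would do at this place on the amide nitrogen, and whether any such group would bring the number back towards that of compound 1 at 24800 nM.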